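A few compounds are considered here, and "the series" means these few. Any claim that something is new, unique, unknown or untested is made for them only; others in the source may bear on it.

Compound 1 `O=C(NO)c1ccc(NCc2nc(-c3cccnc3)nn2-c2ccccc2)cc1` gives 57.7% in an assay on Sf9 cells for inhibition of protein deacetylase HDAC6 (Homo sapiens), read by fluorescence, with a stated time of 40 min, tested at 100 nM (a higher number here means more inhibition at the concentration tested (going by the name of the read-out), a lower number less inhibition), the top of the two numbers measured, though that standing is not separated by the scatter from compound 2 `CC(C)c1ccc(-n2nc(-c3ccccc3)nc2CNc2ccc(C(=O)NO)cc2)cc1`, which gives 52.6% in this assay. Among the compounds with values here, compound 3 `O=C(NO)c1ccc(NCc2nc(-c3ccc(Cl)c(Cl)c3)nn2-c2ccccc2)cc1` is compound 1 with one change: 3,4-dichlorophenyl in place of pyridin-3-yl on an aromatic carbon No measured pair isolates this change, so its size is unknown. Compound 3 is expected to show a number 0.7 percentage points lower from compound 1 to compound 3 (within the scatter), a step within the scatter. Compound 3 is therefore estimated in this assay at 57%, between 40% and 74%.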

Compound 3, a percentage reported as inhibition, at one concentration (the size of the read-out at that concentration, not a potency): 34.5%
The estimate for compound 3 lay 22.5 percentage points above the measured number; the whole stated range lies above it.
By their numbers in this assay, from the lowest: compound 3; then compounds 2 and 1 (each within the scatter of the next).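

Replacing pyridin-3-yl with 3,4-dichlorophenyl gives a number 23.2 percentage points lower from compound 1 to compound 3 (beyond the scatter) in this assay, the first step beyond the scatter among these compounds. It shows that inhibition at this concentration depends on the ring carried by this aromatic carbon, between two ring nitrogen atoms. No available evidence accounts for this step.

On these data alone, whether the step follows the two chlorine atoms or the loss of the ring nitrogen remains open, as this one change combines both. As far as these compounds go, how a morpholine or a carboxylic acid on this ring would read also remains open.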